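This account rests on a few compounds, and the source may have more. Where it says the series, first, only, none or still open, it means among the compounds named here.

Compound 1 `CCCCc1cnc(Cc2ccc(-c3ccccc3C(=O)O)cc2)[nH]1`: > 10000 nM
Compound 2 `COc1ccc(Cc2cnc(CCc3ccc(-c4ccccc4C(=O)O)cc3)[nH]2)cc1`: 5360 nM
Compound 3 `CCCCc1cnc(C(CCCC)Cc2ccc(-c3ccccc3C(=O)O)cc2)[nH]1`: 2660 nM

In an in vitro functional assay on cells for agonist activity at Bombesin receptor subtype-3 (Homo sapiens), read by luminescence and calcium flux (a lower number here means that less compound is needed, a higher number that more compound is needed for the effect), compound 2 gives 5360 nM, the higher of the two numbers shown. Compound 3 gives 2660 nM, which lies within the usual scatter of compound 2, so the two cannot be told apart on these data. For compound 1 the assay reports only a limit, > 10000 nM (the limit of > 10000 nM in this assay, at which 1 of the 3 values shown sits). Compound 4 `O=C(O)c1ccccc1-c1ccc(CCc2ncc(CC3CC3)[nH]2)cc1` differs from compound 2 in a single place (cyclopropyl in place of 4-methoxyphenyl on a saturated chain carbon bound to an aromatic carbon). Within the data shown here, no measured pair shows this same change, so the expectation rests on compound 2 alone. A modest shift toward a higher number, just beyond the scatter, is expected: a 1.7-fold higher number from compound 2 to compound 4 (0.23 log units; within the scatter). Compound 4 is estimated at 9000 nM, within a range from 2500 nM to 30000 nM.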

Compound 4, half-maximal effective concentration: 1000 nM
Beside the measured number, compound 4's estimate is 9.0-fold (0.95 log units) above it; the measured number lies below the stated range.
By their numbers in this assay, from the lowest: compound 4; then compounds 3 and 2 (each within the scatter of the next). At a limit, above all of these: compound 1.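

In this assay, cyclopropyl in place of 4-methoxyphenyl on a saturated chain carbon bound to an aromatic carbon gives a 5.4-fold lower number from compound 2 to compound 4 (0.73 log units; beyond the scatter), so this place does not need the six-membered aromatic ring. A three-membered non-aromatic ring of carbon only, with fewer heavy atoms and no hydrogen-bond acceptor, is enough here and gives the lower number. Nothing measured here explains why the number falls with this change. Open, as far as these compounds go, is whether a cyclohexyl ring or an amine at this place would lower the number further. Also open, from the compounds shown here alone, is whether this change would have the same effect on another core.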